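The source may hold more compounds than are shown below. What is called first, only, known or untested is meant among the compounds shown, and "the series" means these compounds.

Of the compounds shown here, three have so far been tested in a toxicity assay on BJ cells (Homo sapiens) for cytotoxicity, read by MTT assay, with a stated time of 24 h; on this read-out lower numbers stand for stronger inhibition and higher numbers for weaker inhibition. Compound 1, `CCOC(=O)N1CCC(=NNC(=O)c2ccc(F)cc2)CC1`, gives > 400000 nM, which is a limit of the assay rather than a measured number. Compound 2, `CCOC(=O)N1CCC(=NNC(=O)c2ccc([N+](=O)[O-])cc2[N+](=O)[O-])CC1`, gives > 400000 nM, again a limit. Compound 3, `O=C(NN=C1CC(c2ccccc2)NC(c2ccccc2)C1)c1ccc(Cl)cc1`, likewise gives > 400000 nM, once more a limit. Compound 3 therefore stands exactly where every value shown stands, at the edge of what this assay can report, and none of the three compounds shows toxicity toward these cells that the assay can put a number on.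

The untested compound 4, `COc1ccc(C(=O)NN=C2CC(c3ccccc3)NC(c3ccccc3)C2)cc1`, differs from compound 3 in a single place: methoxy in place of chloro on an aromatic carbon. Within the data shown here, no pair of measured compounds differs in only one place, so no measured step tells how such a swap shifts this read-out. What the data do give is the limit of > 400000 nM in this assay, at which 3 of the 3 values shown sit, and on that ground no step beyond the usual scatter is expected in either direction. Compound 4 is accordingly expected to sit at the same limit, with an estimate of 500000 nM and a range from 200000 nM to 2000000 nM. The expected step, a step that the limit leaves unreadable from compound 3 to compound 4, amounts to nothing beyond the scatter of this assay.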

Compound 4, half-maximal inhibitory concentration: > 400000 nM
Compound 4: no number, only a limit; the forecaster's own chance of this, stated with the estimate: 85%; the middle value does not contradict the limit.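

Compound 3 and compound 4 both give only a limit, so the swap of chloro for methoxy yields no readable step: the limit of > 400000 nM in this assay, at which 4 of the 4 values shown sit.

The compounds shown leave open whether any compound of this kind has a toxicity that this assay can put a number on, and how this swap would shift such a number.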